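From Isobutoxy to Methylsulfanyl in a Small Acid Series

The source may hold more compounds than are shown below. What is called first, only, known or untested is meant among the compounds shown, and "the series" means these compounds.

Of the compounds shown here, three have been measured in a functional assay on the whole organism (strain Sprague-Dawley) for inhibition, with Rattus norvegicus as the target, with a stated time of 10 min; on this read-out lower numbers stand for an effect already at smaller amounts and higher numbers for an effect only at larger amounts of compound. Compound 1 `O=C(O)c1cnc(-c2ccccc2)[nH]c1=O` gives 50 mg/kg. Compound 2 `O=C(O)c1cnc(-c2ccccc2[N+](=O)[O-])[nH]c1=O` gives > 50 mg/kg, which is a limit of the assay and not a number. Compound 3 `CC(C)COc1ccccc1-c1ncc(C(=O)O)c(=O)[nH]1` gives 0.5 mg/kg, the lower of the two actual numbers, and it stands clear of both others: a 100-fold lower number from compound 1 to compound 3 (2.00 log units; beyond the scatter), and an at least 100-fold lower number from compound 2 to compound 3 (2.00 log units; beyond the scatter).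

Compound 4 `CSc1ccccc1-c1ncc(C(=O)O)c(=O)[nH]1` is still unmeasured. It differs from compound 3 by one change, (methylsulfanyl in place of isobutoxy on an aromatic carbon), with methylsulfanyl in place of isobutoxy on an aromatic carbon of a six-membered aromatic ring of carbon only, ortho to a large group.

Two measured steps show how much a group at this place can matter. Isobutoxy brought a 100-fold lower number from compound 1 to compound 3 (2.00 log units; beyond the scatter), whereas nitro gave a number no lower from compound 1 to compound 2 (the limit leaves the size open), so a group here does not guarantee a gain. Neither step tests methylsulfanyl itself, so the expectation is loose: compound 4 should keep part of the gain seen for compound 3 but lose some of it. The estimate is a moderate step toward a higher number in this assay, namely a 6.0-fold higher number from compound 3 to compound 4 (0.78 log units; beyond the scatter). Compound 4 is expected at 3 mg/kg, with an estimated range from 0.6 mg/kg to 20 mg/kg.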

Compound 4, dose for 50% inhibition: > 20 mg/kg
Compound 4 was reported as a limit; the forecaster's own chance of this, stated with the estimate: 10%; at least 6.6-fold (0.82 log units) between middle value and limit.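

In this assay, the change on the aromatic carbon gives an at least 40-fold higher number from compound 3 to compound 4 (1.60 log units; beyond the scatter), so the large gain seen with isobutoxy does not carry over to every small chain placed here. Isobutoxy and methylsulfanyl have the same counts, with 0 hydrogen-bond donors, 1 hydrogen-bond acceptor and no net charge, so these counts alone do not account for the gain; the two groups do differ in their atoms, with 5 heavy atoms leaving and 2 entering, and with sulfur in place of oxygen. From the compounds shown here alone, compound 4 gives > 20 mg/kg, which is a limit and not a number, and because of it the steps from compound 1 and from compound 2 to compound 4 cannot be read, so whether methylsulfanyl brings any gain over hydrogen stays unknown: the limit of > 20 mg/kg in this assay, at which 1 of the 4 values shown sits.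

The compounds shown do not separate the effect of the oxygen from that of the chain length, since the oxygen group has the longer, branched chain and the sulfur group the short one. Going by these compounds, a methoxy group or an isobutylsulfanyl group at this place would pull these two apart, and it remains open which of the two differences matters.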